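Swapping the 4-chlorophenyl of compound 3

The compounds below may be only part of what the source reports. "The series", "measured", "known", "first", "only" and "open" are said of these compounds alone.

Compound 1 `CCCc1nc2ccccn2c1C(=O)NCc1ccc(-c2ccccc2)cc1`: 0.373 h
Compound 2 `CCc1nc2ccc(Cl)cn2c1C(=O)NCc1ccc(-c2ccccc2Cl)cc1`: 0.648 h
Compound 3 `CCc1nc2cc(Cl)ccn2c1C(=O)NCc1ccc(-c2ccc(Cl)cc2)cc1`: > 2 h

In an ADME assay (liver) for metabolic stability, with Liver microsome (Homo sapiens) as the target, using microsomes (on this read-out higher numbers stand for a longer-lived compound and lower numbers for a shorter-lived compound), compound 3 gives > 2 h, which is a limit of the assay and not a number. Compound 4 `CCc1nc2cc(Cl)ccn2c1C(=O)NCc1ccc(N2CCC(Cl)CC2)cc1` carries 4-chloropiperidin-1-yl in place of 4-chlorophenyl on an aromatic carbon, para to a large group: 4-chloropiperidin-1-yl in place of 4-chlorophenyl on an aromatic carbon. Among the compounds with values here, no measured pair shows this change directly, so a shorter half-life is expected only tentatively. Compound 1 gives 0.373 h and compound 2 gives 0.648 h, so half-lives of that size do occur in this set. The estimated step is an at least 2.2-fold lower number from compound 3 to compound 4 (0.34 log units; beyond the scatter). For compound 4 the estimate is 0.9 h, with an expected range of 0.35 h to 2 h.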

Compound 4, half-life: 0.183 h
Compound 4: middle estimate off by 4.9-fold (0.69 log units), on the high side, and the stated range ends above it.
By their numbers in this assay, from the lowest: compound 4; then compounds 1 and 2 (each within the scatter of the next). At a limit, above all of these: compound 3.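

In this assay, 4-chloropiperidin-1-yl in place of 4-chlorophenyl on this aromatic carbon, para to a large group, gives an at least 10-fold lower number from compound 3 to compound 4 (1.03 log units; beyond the scatter). Within the data shown here, this is the first step between compounds differing in one place, and it shows that the half-life of this series can depend strongly on the ring at this position. The size of the step is only a bound, as the value for compound 3 is a limit: the limit of > 2 h in this assay, at which 1 of the 4 values shown sits.

On these data alone, whether the step follows from the saturated ring, its nitrogen or its chlorine stays open. A plain piperidin-1-yl or a morpholin-4-yl at this place would help separate these.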